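The source may hold more compounds than are shown below. What is called first, only, known or untested is meant among the compounds shown, and "the series" means these compounds.

Working notes on the series. The core is shared; compound 1 `Cc1c(O)c(C)c2c(c1O)C(=O)CC(c1ccccc1O)O2` carries a 2-hydroxyphenyl on a saturated ring carbon, compound 2 `Cc1c(O)c(C)c2c(c1O)C(=O)CC(c1cccc(O)c1)O2` a 3-hydroxyphenyl, and compound 3 `Cc1c(O)c(C)c2c(c1O)C(=O)CC(c1ccc(O)c(O)c1)O2` adds a hydroxy in place of hydrogen on an aromatic carbon. In a functional assay on HUVEC cells (Homo sapiens) (on this read-out higher numbers stand for an effect only at larger amounts of compound and lower numbers for an effect already at smaller amounts), compound 1 gives only a limit, > 20000 nM. Compound 2 likewise gives only a limit in this assay, > 20000 nM. Compound 3 also gives only a limit, > 20000 nM. Compound 2 thus stands at the limit, as do the two other measured values, (the limit of > 20000 nM in this assay, at which 3 of the 3 values shown sit). The step that the two limits leave unreadable from compound 1 to compound 2 cannot be read, nor can a step that the two limits leave unreadable from compound 2 to compound 3.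

Compound 4 `Cc1c(O)c(C)c2c(c1O)C(=O)CC(c1ccccc1Cl)O2` differs from compound 2 by 2-chlorophenyl in place of 3-hydroxyphenyl on a saturated ring carbon. Both measured steps concern the group on a saturated ring carbon, and neither is readable, so no size or direction can be taken from them. The expectation is that a step that the limit leaves unreadable from compound 2 to compound 4 is a step of no readable size. Compound 4 is therefore expected to sit at the same limit, with an estimated 30000 nM, in a range from 8000 nM to 100000 nM in this assay.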

Compound 4, half-maximal effective concentration: > 20000 nM
Compound 4: no number, only a limit; the forecaster's own chance of this, stated with the estimate: 80%; the middle value does not contradict the limit.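

Going by these compounds alone, compound 4 gives only a limit, so no step from compound 1 or compound 2 to compound 4 can be read: the limit of > 20000 nM in this assay, at which 4 of the 4 values shown sit. In this assay the compounds shown leave open which group on a saturated ring carbon, if any, would give a value that is a number.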